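Adding a methoxy group to the saturated phenethyl analogue

The source may report more compounds than this note shows. Statements on the series, on what has been measured and on what is new or still open speak of the compounds shown alone.

In an assay on mitochondria (strain BALB/c) for inhibition of glycerol-3-phosphate acyltransferase 1, mitochondrial (Mus musculus), read by scintillation counting, with a stated time of 10 min (a lower number here means a stronger inhibitor, a higher number a weaker inhibitor), compound 2 `CCCCCCCCS(=O)(=O)Nc1cc(CCc2ccccc2)ccc1C(=O)O` gives 37500 nM. Compound 1 `CCCCCCCCS(=O)(=O)Nc1cc(/C=C/c2ccc(OC)cc2)ccc1C(=O)O` gives 38700 nM in this assay, and the step of a 1.0-fold lower number from compound 1 to compound 2 (0.01 log units; within the scatter) leaves the two compounds within the scatter of each other. Compound 3 `CCCCCCCCS(=O)(=O)Nc1cc(CCc2ccc(OC)cc2)ccc1C(=O)O` differs from compound 2 by methoxy in place of hydrogen on an aromatic carbon. For the measured compounds named here, the only measured step that bears on this change, a 1.0-fold lower number from compound 1 to compound 2 (0.01 log units; within the scatter), combines two alterations and therefore sets no direction. Compound 3 is thus expected to show no step beyond the scatter, a 1.0-fold lower number from compound 2 to compound 3 (0.01 log units; within the scatter). The estimate for compound 3 is 37000 nM, between 15000 nM and 90000 nM.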

Compound 3, half-maximal inhibitory concentration: 43000 nM
The estimate for compound 3 lay 1.2-fold (0.07 log units) below the measured number; the measured number falls inside the stated range.
By their numbers in this assay, from the lowest: compounds 2, 1 and 3 (each within the scatter of the next).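

In this assay the methoxy group on the saturated phenethyl group can now be read alone: a 1.1-fold higher number from compound 2 to compound 3 (0.06 log units; within the scatter) shows that adding it at this place leaves the number within the scatter. With the methoxy held fixed, 2-(4-methoxyphenyl)ethyl in place of 2-(4-methoxyphenyl)ethenyl gives a 1.1-fold higher number from compound 1 to compound 3 (0.05 log units; within the scatter) and so also stays within the scatter, which separates the two alterations that the earlier step combined. Nothing available explains either result. From the compounds shown here alone, whether an amine or a carboxylic acid at this place, or a longer chain in place of the methoxy, would move the number beyond the scatter remains open.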